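A few compounds are considered here, and "the series" means these few. Any claim that something is new, unique, unknown or untested is made for them only; others in the source may bear on it.

Measured compounds:
compound 1, `CCCNC(=O)/N=C(\N)NCCCc1sc(N)nc1C`, gives 105 nM in an assay on membranes from Sf9 cells for displacement of a labelled ligand from histamine H2 receptor (Homo sapiens), read by scintillation counting, with a stated time of 60 min; on this read-out higher numbers stand for weaker inhibition and lower numbers for stronger inhibition
compound 2, `Cc1nc(N)sc1CCCN/C(N)=N/C(=O)NCC(C)C1CCCCC1`, gives 39.8 nM in this assay

Among the measured compounds shown here, compound 2 stands with the lowest of the two numbers in this assay; its only neighbour is compound 1, separated by a 2.6-fold lower number from compound 1 to compound 2 (0.42 log units; beyond the scatter). Compound 3, `Cc1ccc(CC(C)CNC(=O)/N=C(\N)NCCCc2sc(N)nc2C)cc1`, has not yet been measured. It differs from compound 2 by 4-methylbenzyl in place of cyclohexyl on a saturated chain carbon bound to two saturated chain carbons. For the measured compounds named here, only one measured step bears on this position: a 2.6-fold lower number from compound 1 to compound 2 (0.42 log units; beyond the scatter), which introduced cyclohexyl onto the bare chain carbon. That step shows the position tolerates, and even favours, a six-membered carbon ring. Going by the values given here, compound 3 keeps a carbon ring there, now an aromatic one carrying a further methyl and joined through an extra chain atom; no measured pair tells how such an exchange of one ring for another plays out. The expectation is therefore a number close to that of compound 2, with no step beyond the scatter in this assay. Compound 3 is expected to give about 35 nM, within a range from 12 nM to 110 nM. The step this estimate means is expected to be a 1.1-fold lower number from compound 2 to compound 3 (0.06 log units; within the scatter).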

Compound 3, inhibition constant: 72.4 nM
Estimate against measurement, compound 3: 2.1-fold (0.32 log units) below; the measured number falls inside the stated range.
By their numbers in this assay, from the lowest: compounds 2, 3 and 1 (each within the scatter of the next, the first and the last beyond it).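

On the saturated chain carbon bound to two saturated chain carbons, 4-methylbenzyl is accepted in place of cyclohexyl: in this assay the exchange gives a 1.8-fold higher number from compound 2 to compound 3 (0.26 log units; within the scatter) and so cannot be told apart from the scatter. Set against the bare chain carbon, 4-methylbenzyl gives a 1.5-fold lower number from compound 1 to compound 3 (0.16 log units; within the scatter) while cyclohexyl gave a 2.6-fold lower number from compound 1 to compound 2 (0.42 log units; beyond the scatter) and therefore only cyclohexyl stands clear of the compound without a ring. Compound 3 thus lies within the scatter of both compound 1 and compound 2, so the gain seen with cyclohexyl is not shown to carry over to the aromatic ring, nor is it shown to be lost. Nothing given here offers an explanation for these numbers.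

The compounds shown leave open how plain benzyl or a phenyl set directly on this chain carbon would compare with 4-methylbenzyl, which would separate the contributions of the ring, the methyl and the joining carbon. Also open, as far as these compounds go, is how an amine, a carboxylic acid or a longer chain would fare at this carbon.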